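Swapping a Five-Membered Ring on a Shared Core

The source may hold more compounds than are shown below. What is called first, only, known or untested is meant among the compounds shown, and "the series" means these compounds.

Compound 1 `COCCNC(=O)CNc1ncc2c(Br)nn(-c3ccc4ncccc4c3)c2n1`: > 1000 nM
Compound 2 `COCc1noc([C@@H]2CC[C@@H](Nc3ncc4c(Br)nn(-c5ccc6ncccc6c5)c4n3)C2)n1`: 106 nM

In an assay on isolated protein for inhibition of eIF-2-alpha kinase GCN2 (Homo sapiens) (on this read-out lower numbers stand for stronger inhibition and higher numbers for weaker inhibition), compound 1 reaches only the assay's limit, > 1000 nM, so no number is known for it. Within the data shown here, compound 2 gives 106 nM in this assay, the only number measured. The other entry is the limit of > 1000 nM in this assay, at which 1 of the 2 values shown sits. Compound 3 `Brc1nn(-c2ccc3ncccc3c2)c2nc(N[C@@H]3CC[C@@H](c4ncc[nH]4)C3)ncc12` differs from compound 2 in one place: a group of 5 heavy atoms (3 carbon, 2 nitrogen; one five-membered aromatic ring with 2 hetero atoms) in place of a group of 8 heavy atoms (4 carbon, 2 nitrogen, 2 oxygen; one five-membered aromatic ring with 3 hetero atoms), on a saturated ring carbon. Among the measured compounds shown here, no measured pair differs by a single change, so the size of this step is unknown; a step within the scatter, in either direction, is expected. Compound 3 is expected to give about 150 nM in this assay, between 40 nM and 600 nM, which would mean an expected step of a 1.4-fold higher number from compound 2 to compound 3 (0.15 log units; within the scatter).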

Compound 3, half-maximal inhibitory concentration: 21 nM
Compound 3: the middle estimate sits 7.1-fold (0.85 log units) above what was measured; measured number below the stated range.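

The saturated ring carbon responds to the choice of five-membered aromatic ring: with 1H-imidazol-2-yl in place of the larger group, this assay shows a 5.0-fold lower number from compound 2 to compound 3 (0.70 log units; beyond the scatter). Against the open chain of compound 1, the same group on its carbon ring gives an at least 47-fold lower number from compound 1 to compound 3 (1.67 log units; beyond the scatter), a size that is only a bound. Compound 1 reaches only a limit of the assay: the limit of > 1000 nM in this assay, at which 1 of the 3 values shown sits.

As far as these compounds go, whether the change follows the ring itself or the smaller group stays open. So does how a 1-methylimidazol-2-yl group or a simple amine on the same carbon would read.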